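Notes on the pendant arm: estimate for compound 4

A few compounds are considered here, and "the series" means these few. Any claim that something is new, unique, unknown or untested is made for them only; others in the source may bear on it.

Measured so far in a functional assay on MDA-MB-231 cells (Homo sapiens) for cytotoxicity, read by MTT assay, with a stated time of 72 h; on this read-out higher numbers stand for weaker inhibition and lower numbers for stronger inhibition:
- compound 1 `O=C1c2c[n+]([O-])c3ccccc3c2C(=O)c2c1c1ccccc1n2Cc1cn(C[C@@H](O)CO)nn1` gives 670 nM
- compound 2 `CN1CCN(CCCn2c3c(c4ccccc42)C(=O)c2c[n+]([O-])c4ccccc4c2C3=O)CC1` gives 390 nM
- compound 3 `CCCN1CCN(CCCCn2c3c(c4ccccc42)C(=O)c2c[n+]([O-])c4ccccc4c2C3=O)CC1` gives 2980 nM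

Compound 1 stands second highest of the three numbers. Its nearest neighbour is compound 2, a 1.7-fold lower number from compound 1 to compound 2 (0.24 log units; within the scatter), which is within the scatter. Its furthest is compound 3, a 4.4-fold higher number from compound 1 to compound 3 (0.65 log units; beyond the scatter), a modest weakening. Between the two piperazine compounds the gap is a 7.6-fold higher number from compound 2 to compound 3 (0.88 log units; beyond the scatter).

Compound 4 `O=C1c2c[n+]([O-])c3ccccc3c2C(=O)c2c1c1ccccc1n2Cc1cn([C@@H]2O[C@H](CO)[C@@H](O)[C@H](O)[C@H]2O)nn1` is not yet measured. It differs from compound 1 in one place: 3,4,5-trihydroxy-6-(hydroxymethyl)oxan-2-yl in place of 2,3-dihydroxypropyl on an aromatic nitrogen.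

For the measured compounds named here, no measured step changes the group on the triazole nitrogen; the two steps from compound 1 replace the whole arm on the saturated chain carbon bound to the aromatic nitrogen, and they span only a modest range, from within the scatter to a modest weakening. They show that the shared core keeps activity in this assay under varied arms, but they say nothing specific about the sugar. The step from compound 1 to compound 4 is therefore expected to be small, with a slight lean toward a higher number, a 1.3-fold higher number from compound 1 to compound 4 (0.13 log units; within the scatter).

Compound 4 is estimated at 900 nM, in the range 350 nM to 2500 nM.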

Compound 4, half-maximal inhibitory concentration: 650 nM
Estimate against measurement, compound 4: 1.4-fold (0.14 log units) above, and the stated range covers the measured number.
By their numbers in this assay, from the lowest: compounds 2, 4 and 1 (each within the scatter of the next); then compound 3.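

In this assay, 3,4,5-trihydroxy-6-(hydroxymethyl)oxan-2-yl in place of 2,3-dihydroxypropyl on the aromatic nitrogen of the five-membered aromatic ring gives a 1.0-fold lower number from compound 1 to compound 4 (0.01 log units; within the scatter), and this is the only step shown that changes this group alone. The read-out does not separate the two groups, although the entering group has 11 heavy atoms against 5, a six-membered non-aromatic ring and 5 defined stereocentres against 1, so this position accepts a much larger, ring-bearing group in this assay, something the earlier replacements of the whole arm could not show. No independent data are available to explain why the two groups read alike.

On these data alone, with only these two groups on this nitrogen, it remains open whether a simple methyl, a primary amine, a carboxylic acid or a longer chain such as 4-hydroxybutyl would read the same way. Also open is whether the result depends on the stereochemistry of the oxane ring, since only one arrangement of its 5 defined stereocentres appears among the compounds shown.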